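The source may report more compounds than this note shows. Statements on the series, on what has been measured and on what is new or still open speak of the compounds shown alone.

The measured compounds:

Compound 1, `O=C1C2CCCCN2C(=O)N1CN1CCN(c2cccc(Cl)c2)CC1`, gives 135 nM in an assay on isolated protein for binding affinity to Adrenergic receptor alpha-1 (Rattus norvegicus), read by radioligand binding; a higher number here means a weaker inhibitor, a lower number a stronger inhibitor.
Compound 2, `O=C1C2CCCCN2C(=O)N1CN1CCN(c2cccc(C(F)(F)F)c2)CC1`, gives > 1000 nM in this assay; this is a limit of the assay, not a number.
Compound 3, `O=C1C2CCCCN2C(=O)N1CCN1CCN(c2cccc(Cl)c2)CC1`, gives 375 nM in this assay.

Compound 1 and compound 2 share one core and differ in a single place: trifluoromethyl in place of chloro on an aromatic carbon. This change produced an at least 7.4-fold higher number from compound 1 to compound 2 (0.86 log units; beyond the scatter). The step is open at its upper end because the limit of > 1000 nM in this assay, at which 1 of the 3 values shown sits, applies to compound 2.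

Compound 3 carries a different core from compound 1; the difference between the two cores is not broken down here. In this assay compound 3 stands a step above compound 1, the nearest measured neighbour, and that gap lies beyond the scatter.

Compound 4, `O=C1C2CCCCN2C(=O)N1CCN1CCN(c2cccc(C(F)(F)F)c2)CC1`, has not yet been measured. It stands to compound 3 as compound 2 stands to compound 1: trifluoromethyl in place of chloro on an aromatic carbon. The place is described in the same words for both pairs, so this is the same change made on the second core.

Compound 4 is expected to give about 2800 nM in this assay, with a likely span from 1000 nM to 10000 nM. Among the measured compounds shown here, the expected step of a 7.5-fold higher number from compound 3 to compound 4 (0.87 log units; beyond the scatter) rests on the measured step of an at least 7.4-fold higher number from compound 1 to compound 2 (0.86 log units; beyond the scatter), the only example of this change so far, and with one example the size carried over to the second core is uncertain. Since that earlier change already reached the limit of the assay, compound 4 may well return only a limit rather than a number.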

Compound 4, inhibition constant: > 1000 nM
Compound 4: no number, only a limit; the forecaster's own chance of this, stated with the estimate: 75%; the middle value does not contradict the limit.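

In this assay compound 4 gives > 1000 nM, which is a limit of the assay and not a number, and it joins compound 2 in this respect: the limit of > 1000 nM in this assay, at which 2 of the 4 values shown sit.

Trifluoromethyl in place of chloro on an aromatic carbon gave an at least 2.6-fold higher number from compound 3 to compound 4 (0.42 log units; beyond the scatter), so on both cores shown the change leads the same way, to a higher number and thus a weaker inhibitor, and no compound shown goes against this. Among the compounds shown here, with only two cores, this direction is all that carries over, and it cannot be taken as a rule for other cores. The true size of the change remains unknown on either core, and the two steps cannot be said to agree or to differ in size: the same change on two cores in this assay, an at least 7.4-fold higher number (0.86 log units; beyond the scatter) from compound 1 to compound 2 and an at least 2.6-fold higher number (0.42 log units; beyond the scatter) from compound 3 to compound 4; the limit leaves it open whether they differ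

The compounds shown carry only chloro or trifluoromethyl in this place on the aromatic ring, so it remains open how a fluoro, a methoxy or a nitrile group there would read in this assay. As far as these compounds go, it also remains open whether a longer chain in the core would give the same direction for this change, and a trifluoromethyl compound that returns a number rather than a limit would be needed to size the step.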